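Replacing a methylsulfonyl group on a ring amine nitrogen

The compounds below may be only part of what the source reports. "The series", "measured", "known", "first", "only" and "open" are said of these compounds alone.

In a toxicity assay on MT4 cells (Homo sapiens) for cytotoxicity, read by MTT assay, with a stated time of 7 days (on this read-out higher numbers stand for lower toxicity in this test and lower numbers for higher toxicity in this test), compound 1 (`Cc1cc(C)cc(S(=O)(=O)c2c(C(N)=O)[nH]c3ccc(Cl)cc23)c1`) gives 5520 nM and compound 3 (`Cc1cc(C)cc(S(=O)(=O)c2c(C(=O)NC3CC4(CCNCC4)C3)[nH]c3ccc(Cl)cc23)c1`) gives 24200 nM. Compound 2 (`Cc1cc(C)cc(S(=O)(=O)c2c(C(=O)NC3CC4(C3)CN(S(C)(=O)=O)C4)[nH]c3ccc(Cl)cc23)c1`) gives > 233000 nM, which is a limit of the assay and not a number. Compound 4 (`Cc1cc(C)cc(S(=O)(=O)c2c(C(=O)NC3CC4(C3)CN(Cc3n[nH]c(=O)n3C)C4)[nH]c3ccc(Cl)cc23)c1`) differs from compound 2 thus: a group of 8 heavy atoms (4 carbon, 3 nitrogen, 1 oxygen; one five-membered aromatic ring with 3 hetero atoms) in place of a group of 4 heavy atoms (1 carbon, 2 oxygen, 1 sulfur; no ring), on an amine nitrogen in a ring. Among the compounds with values here, no measured step changes this group alone. The nearest evidence is an at least 9.6-fold lower number from compound 2 to compound 3 (0.98 log units; beyond the scatter), at least modest, alongside the large at least 42-fold higher number from compound 1 to compound 2 (1.62 log units; beyond the scatter) and the modest 4.4-fold higher number from compound 1 to compound 3 (0.64 log units; beyond the scatter). Those steps show that this assay responds to changes on the amide-type nitrogen, so a modest step towards a lower number is expected. The estimated step is an at least 2.1-fold lower number from compound 2 to compound 4 (0.32 log units; beyond the scatter). Compound 4 is estimated at 110000 nM, with an expected range of 40000 nM to 240000 nM.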

Compound 4, half-maximal cytotoxic concentration: 65600 nM
Compound 4: the middle estimate sits 1.7-fold (0.22 log units) above what was measured; low and high end bracket the measured number.
By their numbers in this assay, from the lowest: compound 1; then compound 3; then compound 4. At a limit, above all of these: compound 2.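

In this assay, putting the group with the five-membered aromatic ring in place of methylsulfonyl gives an at least 3.5-fold lower number from compound 2 to compound 4 (0.55 log units; beyond the scatter). Within the data shown here, this shows that the read-out also responds to a change on the amine nitrogen in a ring, whereas the earlier steps were all described on the amide-type nitrogen. Compound 2 stands at a limit of the assay and not at a number: the limit of > 233000 nM in this assay, at which 1 of the 4 values shown sits.

On these data alone, the full size of this step therefore remains open. So does the response on this same nitrogen to a smaller group, such as acetyl or methyl, or to a carboxylic acid.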